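Extending the amide aryl group in an aromatase inhibitor series

The compounds below may be only part of what the source reports. "The series", "measured", "known", "first", "only" and "open" are said of these compounds alone.

Measured compounds:
- compound 1, `CN(c1ccc(N)cc1OCc1ccccc1)S(C)(=O)=O`: 1100 nM
- compound 2, `CN(c1ccc(NC(=O)c2ccccc2)cc1OCc1ccccc1)S(C)(=O)=O`: 1770 nM

In an assay on SK-BR-3 cells for inhibition of Aromatase (Homo sapiens) (a higher number here means a weaker inhibitor, a lower number a stronger inhibitor), compound 1 gives 1100 nM, and compound 2 gives 1770 nM. Compound 2 holds the highest of the two numbers, though the step of a 1.6-fold higher number from compound 1 to compound 2 (0.21 log units; within the scatter) means the two values cannot be told apart.

Compound 3, `CN(c1ccc(NC(=O)c2ccc3ccccc3c2)cc1OCc1ccccc1)S(C)(=O)=O`, is not yet measured. It differs from compound 2 by naphthalen-2-yl in place of phenyl on a carbonyl carbon. Among the compounds with values here, the only measured step changes what sits on the amide nitrogen, not the ring on the carbonyl carbon, so it offers no direct guide to this change; it shows only that adding the benzoyl group left the number about where it was.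

With nothing shown to the contrary, compound 3 is expected to stay close to compound 2, with a 1.0-fold higher number from compound 2 to compound 3 (0.01 log units; within the scatter) within the scatter in this assay. The estimate for compound 3 is 1800 nM, expected to fall between 600 nM and 5500 nM.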

Compound 3, half-maximal inhibitory concentration: 1070 nM
Beside the measured number, compound 3's estimate is 1.7-fold (0.23 log units) above it; low and high end bracket the measured number.
By their numbers in this assay, from the lowest: compounds 3, 1 and 2 (each within the scatter of the next).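

In this assay, putting naphthalen-2-yl in place of phenyl on the carbonyl carbon gives a 1.7-fold lower number from compound 2 to compound 3 (0.22 log units; within the scatter) and the two values cannot be told apart. Within the data shown here, the earlier compounds showed only that the benzoyl group could sit on the nitrogen; this step adds that the ring on the carbonyl carbon can grow from 6 to 10 heavy atoms, gaining a second six-membered aromatic ring, with no measurable difference in this read-out. No measurement shown here explains this result.

Still open, as far as these compounds go, is whether any group on the carbonyl carbon can move the number beyond the scatter, such as a pyridine ring, a short alkyl chain, or a phenyl ring carrying a carboxylic acid or an amine. A single pair of aromatic groups cannot settle how much this position matters.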